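A few compounds are considered here, and "the series" means these few. Any claim that something is new, unique, unknown or untested is made for them only; others in the source may bear on it.

Of the compounds shown here, two built on one shared core have been tested in a functional assay on PC-3 cells (Homo sapiens) for inhibition, read by MTT assay, with a stated time of 72 h; a higher number here means a weaker inhibitor, a lower number a stronger inhibitor. Compound 1, with structure `CC(C)n1ncc2c(C(=O)NCc3cn(-c4ccc(I)cc4)nn3)cccc21`, gives a limit rather than a number there: in this assay compound 1 reads > 40000 nM. Among the measured compounds shown here, compound 2, with structure `CC(C)n1ncc2c(C(=O)NCc3cn(-c4cccc(Br)c4)nn3)cccc21`, is the only one of the pair with a measured number, and in this assay compound 2 gives 33700 nM. The step between them, an at least 1.1-fold lower number from compound 1 to compound 2 (0.07 log units; that floor lies within the scatter), is too small to separate from the scatter of repeated tests, and it is tied to the limit of > 40000 nM in this assay, at which 1 of the 2 values shown sits.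

Compound 3, with structure `CC(C)n1ncc2c(C(=O)NCc3cn(-c4cccc(F)c4)nn3)cccc21`, differs from compound 2 in a single place: fluoro in place of bromo on an aromatic carbon. For the measured compounds named here, the only measured step exchanges one halogenated phenyl ring for another and barely moves the number, so a further halogen exchange on that ring gives no ground to expect a step in this assay beyond the scatter, in either direction. Compound 3 is therefore expected to remain a weak inhibitor, at an estimated 38000 nM, within a likely range from 15000 nM to 100000 nM. That estimate means an expected step of a 1.1-fold higher number from compound 2 to compound 3 (0.05 log units; within the scatter).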

Compound 3, half-maximal inhibitory concentration: 36100 nM
For compound 3 the middle estimate is 1.1-fold (0.02 log units) above the measured one, and the stated range covers the measured number.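

In this assay, among the compounds shown here, the change from 3-bromophenyl to 3-fluorophenyl gives a 1.1-fold higher number from compound 2 to compound 3 (0.03 log units; within the scatter) and is the first step here that joins two measured numbers rather than a number and a limit. It shows that, at this place on the phenyl ring, two different halogens read alike, and that compound 2 and compound 3 both stay among weak inhibitors. Compound 1 gives only a limit, so its comparison reads as an at least 1.1-fold lower number from compound 1 to compound 3 (0.04 log units; that floor lies within the scatter) and shows a floor and no more, which means the 4-iodophenyl group cannot be ranked against the 3-fluorophenyl group, and this comparison rests on that limit: the limit of > 40000 nM in this assay, at which 1 of the 3 values shown sits.

The compounds shown carry only halogens on this phenyl ring, so it remains open whether an amine, a carboxylic acid or a methoxy group at this place would move the number beyond the scatter. Going by these compounds, it also remains open whether any change elsewhere on the shared core would bring a stronger inhibitor in this kind of test on these cells.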